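A few compounds are considered here, and "the series" means these few. Any claim that something is new, unique, unknown or untested is made for them only; others in the source may bear on it.

Measured so far in an assay for inhibition of HSP60/HSP10 (Homo sapiens), with a stated time of 60 min; a lower number here means a stronger inhibitor, a higher number a weaker inhibitor:
Compound 1 `O=C(Nc1ccc(Sc2nc3ccccc3s2)cc1)c1ccccc1` gives > 100000 nM, which is a limit of the assay.
Compound 2 `O=C(Nc1ccc(Sc2nc3ccccc3s2)cc1)c1cccc(Br)c1O` gives 26000 nM.

Within the data shown here, compound 2 thus holds the only numerical value; the other value is a limit. Among the measured compounds shown here, the one measured step, an at least 3.8-fold lower number from compound 1 to compound 2 (0.58 log units; beyond the scatter), rests on (the limit of > 100000 nM in this assay, at which 1 of the 2 values shown sits). Compound 3 `O=C(Nc1ccc(Sc2nc3ccccc3s2)cc1)c1cc(Br)cc(Br)c1O` differs from compound 2 by bromo in place of hydrogen on an aromatic carbon. For the measured compounds named here, only the step from compound 1 to compound 2 bears on this change; it added bromo and hydroxy together, while compound 3 adds a second bromo alone, so a step toward a lower number, no larger than modest, is expected: a 1.7-fold lower number from compound 2 to compound 3 (0.24 log units; within the scatter). Compound 3 is therefore estimated at 15000 nM, between 5000 nM and 45000 nM.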

Compound 3, half-maximal inhibitory concentration: 4700 nM
Compound 3: the middle estimate sits 3.2-fold (0.50 log units) above what was measured; the whole stated range lies above it.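

A second bromo, para to the hydroxy group and meta to the first bromo, brings a gain of its own in this assay: a 5.5-fold lower number from compound 2 to compound 3 (0.74 log units; beyond the scatter). This aromatic carbon therefore still responds once the 3-bromo-2-hydroxyphenyl pattern is in place. Compound 1 stands at a limit of the assay, so the full step, an at least 21-fold lower number from compound 1 to compound 3 (1.32 log units; beyond the scatter), gives only a bound: the limit of > 100000 nM in this assay, at which 1 of the 3 values shown sits.

Open, as far as these compounds go, is how much the hydroxy group contributes without either bromo, and whether the gain at this carbon is particular to bromo. A chloro or methyl group here, or an amine in place of the hydroxy group, would separate these questions.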